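The compounds below may be only part of what the source reports. "The series", "measured", "known", "first", "only" and "open" are said of these compounds alone.

Measured compounds:
- compound 1, `COc1ccc(-c2cc(/C=C/C(=O)c3ccc(N)cc3)[nH]n2)cc1`: 82%
- compound 2, `COc1cc(-c2cc(/C=C/C(=O)c3ccc(Cl)c(Cl)c3)[nH]n2)cc(OC)c1OC`: 85%
- compound 3, `COc1cc(-c2cc(/C=C/C(=O)c3ccc(F)c(F)c3)[nH]n2)cc(OC)c1OC`: 86%

In a functional assay on UO-31 cells (Homo sapiens) for cytotoxicity, read by sulforhodamine B assay, with a stated time of 48 h, tested at 0.1 uM (on this read-out higher numbers stand for a weaker effect at the one concentration tested and lower numbers for a stronger effect), compound 1 gives the lowest of the three numbers, but its gaps to compound 2 and to compound 3 both lie within the scatter, so the three compounds cannot be told apart on this read-out. Going by the values given here, the only step between two compounds that differ in one place is a number 1 percentage points higher from compound 2 to compound 3 (within the scatter), and it concerns the ring on the carbonyl carbon, not the ring carrying the methoxy group.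

Compound 4, `COc1ccc(-c2cc(/C=C/C(=O)c3ccc(N)cc3)[nH]n2)cc1OC`, differs from compound 1 in the following way: methoxy in place of hydrogen on an aromatic carbon. No measured step touches this ring, so the shown data give nothing to argue for a change beyond the scatter in either direction. The three measured numbers sit close together, and a step of about a number 1 percentage points higher from compound 1 to compound 4 (within the scatter) is therefore expected. For compound 4 the estimate in this assay is 83%, with a range from 70% to 96%.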

Compound 4, a percentage reported as activity, at one concentration (the size of the read-out at that concentration, not a potency): 99%
Beside the measured number, compound 4's estimate is 16 percentage points below it; measured number above the stated range.
By their numbers in this assay, from the lowest: compounds 1, 2 and 3 (each within the scatter of the next); then compound 4.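

In this assay, the ring carrying the methoxy group turns out to respond to a small change: the step is a number 17 percentage points higher from compound 1 to compound 4 (beyond the scatter), the only step shown that lies beyond the scatter. On this read-out a higher number means a weaker effect, so methoxy in place of hydrogen, ortho to a methoxy group and meta to a large group, weakens the effect at the one concentration tested, while the change on the other ring, a number 1 percentage points higher from compound 2 to compound 3 (within the scatter), does not separate its two compounds. Nothing shown here gives a measured reason for this loss.

Going by these compounds, it remains open whether the loss belongs to methoxy itself or to any group at this place, which a hydroxyl group, a fluorine atom or an ethoxy group there could help to settle. On these data alone, it also remains open whether the same step would appear with another group in place of the amine on the other ring.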